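Urea aryl swap: methyl to methoxy on the phenyl ring

This account rests on a few compounds, and the source may have more. Where it says the series, first, only, none or still open, it means among the compounds named here.

Measured so far, in an assay on NIH3T3 cells with Urotensin-2 receptor (Homo sapiens) as the target; on this read-out lower numbers stand for an effect already at smaller amounts and higher numbers for an effect only at larger amounts of compound:
compound 1, `Cc1c(Cl)cccc1C(=O)NC(CCN(C)C)c1ccc(Cl)cc1`, gives 1740 nM
compound 2, `Cc1ccccc1NC(=O)NC(CCN(C)C)c1ccc(Cl)cc1`, gives 2290 nM

Compound 2 stands at the higher of the two numbers, with compound 1 nearest; the step of a 1.3-fold higher number from compound 1 to compound 2 (0.12 log units; within the scatter) lies within the usual scatter, so the two cannot be told apart.

The next compound, compound 3, `COc1ccc(NC(=O)NC(CCN(C)C)c2ccc(Cl)cc2)cc1`, differs from compound 2 in one place: 4-methoxyphenyl in place of 2-methylphenyl on an amide-type nitrogen. For the measured compounds named here, the only step measured so far, a 1.3-fold higher number from compound 1 to compound 2 (0.12 log units; within the scatter), changed both the link to the aryl ring and the ring's substituents at once and produced no shift beyond the scatter. Going by the values given here, no measured step alters the substitution of the urea-bound phenyl on its own, so there is no direct guide for this change. Given that the one known aryl change moved the number hardly at all, the expectation for a 1.1-fold higher number from compound 2 to compound 3 (0.04 log units; within the scatter) is a step no larger than the scatter, in no particular direction. Compound 3 is therefore estimated at about 2500 nM, within the range 800 nM to 8000 nM.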

Compound 3, half-maximal effective concentration: 2000 nM
Compound 3: middle estimate off by 1.3-fold (0.10 log units), on the high side; measured number inside the range.
By their numbers in this assay, from the lowest: compounds 1, 3 and 2 (each within the scatter of the next).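

In this assay, putting 4-methoxyphenyl in place of 2-methylphenyl on the amide-type nitrogen gives a 1.1-fold lower number from compound 2 to compound 3 (0.06 log units; within the scatter), so the two compounds cannot be told apart. This is the first step shown that alters only the phenyl group on the urea, since the earlier step altered the link to the ring and the ring's substituents together. For this one pair, a methyl group and a methoxy group, each at its own place on the ring, give numbers that the assay does not separate, and no measurement at hand offers any explanation for that.

As far as these compounds go, because the kind of substituent and its place on the ring differ at once in this pair, the effect of each alone stays open, and 4-methylphenyl or 2-methoxyphenyl on the same nitrogen would be needed to pull them apart. Also open, from the compounds shown here alone, is whether this part of the molecule stays as undemanding with a very different group on the phenyl ring, such as a carboxylic acid or an amine.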